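Cyanoselenyl carbamates: a chloro replaces the hydrogen

This account rests on a few compounds, and the source may have more. Where it says the series, first, only, none or still open, it means among the compounds named here.

Measured so far: compound 1 `N#C[Se]c1ccc(NC(=O)Oc2ccc(F)cc2)cc1` with 6900 nM; compound 2 `N#C[Se]c1ccc(NC(=O)Oc2ccccc2)cc1` with 400 nM.

Going by the values given here, in an ADME assay on 184B5 cells (Homo sapiens) for cytotoxicity, read by MTT assay, with a stated time of 72 h (a lower number here means a stronger inhibitor of growth, a higher number a weaker inhibitor of growth), compound 2 holds the lowest of the two numbers, and the one measured step, a 17-fold lower number from compound 1 to compound 2 (1.24 log units; beyond the scatter), is large. Compound 3 `N#C[Se]c1ccc(NC(=O)Oc2ccc(Cl)cc2)cc1` differs from compound 2 by chloro in place of hydrogen on an aromatic carbon. That earlier step bears directly on it, since there a halogen at the same place gave way to hydrogen and the number fell sharply. A halogen entering again is therefore expected to raise the number, so a 10-fold higher number from compound 2 to compound 3 (1.00 log units; beyond the scatter) is expected. Compound 3 is estimated at 4000 nM, within 800 nM to 20000 nM.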

Compound 3, concentration for 50% growth inhibition: 5600 nM
For compound 3 the middle estimate is 1.4-fold (0.15 log units) below the measured one; the range from low to high includes it.
By their numbers in this assay, from the lowest: compound 2; then compounds 3 and 1 (each within the scatter of the next).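

In this assay, the high number at this place, para to a large group, is not confined to fluoro: chloro in place of hydrogen gives the same kind of large step (a 14-fold higher number from compound 2 to compound 3 (1.15 log units; beyond the scatter)). Exchanging one halogen for the other (a 1.2-fold lower number from compound 1 to compound 3 (0.09 log units; within the scatter)) stays within the scatter, so chloro and fluoro cannot be told apart here. Nothing available explains why either halogen has this effect. On these data alone, whether a methoxy group, an amine or a carboxylic acid at this place would behave like the halogens or like hydrogen remains open.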